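The source may hold more compounds than are shown below. What is called first, only, known or untested is meant among the compounds shown, and "the series" means these compounds.

Compound 3 `C/C(=C\c1cc(-c2ccccc2)cs1)C(N)=O` was tested in a functional assay on A549 cells (Homo sapiens) for cytotoxicity, read by CCK-8 assay, with a stated time of 24 h (on this read-out higher numbers stand for weaker inhibition and lower numbers for stronger inhibition), for its effect on the growth of lung-derived cells. In this assay compound 3 gives only a limit of the assay, > 50000 nM, and no number. Compound 1 `C/C(=C\c1cc(-c2ccc(C)nc2)co1)C(N)=O` also reaches only a limit there, > 50000 nM. Compound 2 `C/C(=C\c1cc(C2=CCCCC2)co1)C(N)=O` likewise sits at a limit, > 50000 nM. Among the measured compounds shown here, every value so far therefore stands at the same edge of this assay (the limit of > 50000 nM in this assay, at which 3 of the 3 values shown sit), and no step between measured compounds has been recorded. Compound 4 `C/C(=C\c1cc(-c2ccc(C(F)(F)F)cc2)cs1)C(N)=O` differs from compound 3 by trifluoromethyl in place of hydrogen on an aromatic carbon. Without any measured step, no shift beyond the scatter is expected, so the expected step of a number no higher from compound 3 to compound 4 (the limit leaves the size open) is small. Compound 4 is expected to give about 50000 nM, between 15000 nM and 50000 nM.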

Compound 4, half-maximal inhibitory concentration: > 50000 nM
Compound 4 was reported as a limit; the forecaster's own chance of this, stated with the estimate: 85%; the middle value sits exactly at the limit.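

Among the compounds shown here, compound 3 and compound 4 both give a limit rather than a number, so no step between them can be read: the limit of > 50000 nM in this assay, at which 4 of the 4 values shown sit. The compounds shown leave open whether trifluoromethyl in place of hydrogen changes their effect on these cells at all.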